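A Cyano Group Added to Compound 2

The source may hold more compounds than are shown below. What is called first, only, known or untested is meant among the compounds shown, and "the series" means these compounds.

Two compounds have been measured in an assay on HEK293 cells for displacement of a labelled ligand from adenosine receptor A2b (Homo sapiens), read by scintillation counting, with a stated time of 30 min, tested at 10 uM; a lower number here means less inhibition, a higher number more inhibition at the concentration tested (going by the name of the read-out):
compound 1, `O=C(NC1CCCC1)c1cc2ccccc2oc1=O`, gives 18%.
compound 2, `COc1cccc2cc(C(=O)Nc3c(C#N)ncn3-c3ccccc3)c(=N)oc12`, gives 9%.

Both numbers are low, meaning little displacement at the tested concentration. On the numbers alone compound 2 sits at the bottom of the pair, but its gap to compound 1 lies within the usual scatter of this kind of measurement, so the two cannot be told apart, and nothing can be said about one being weaker than the other.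

Compound 3, `COc1cccc2cc(C(=O)Nc3c(C#N)ncn3-c3ccc(C#N)cc3)c(=N)oc12`, has not yet been measured. It differs from compound 2 in a single place: cyano in place of hydrogen on an aromatic carbon. Among the measured compounds shown here, no pair of measured compounds shows this same change, so there is no measured step to lean on. Given that both measured values are low and close together, the change is expected to bring only a small step, estimated at a number 3 percentage points higher from compound 2 to compound 3 (within the scatter), with no clear direction beyond the scatter. Compound 3 is therefore expected to give about 12% in this assay, somewhere between 0% and 30%.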

Compound 3, a percentage reported as inhibition, at one concentration (the size of the read-out at that concentration, not a potency): 10%
Compound 3: the middle estimate sits 2 percentage points above what was measured; the range from low to high includes it.
By their numbers in this assay, from the lowest: compounds 2, 3 and 1 (each within the scatter of the next).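

In this assay, putting cyano in place of hydrogen on an aromatic carbon, para to a large group, gives a number 1 percentage points higher from compound 2 to compound 3 (within the scatter), so the two compounds cannot be told apart. Among the compounds shown here, this is the first comparison in the set between compounds that differ in one place only, and it shows that turning phenyl into 4-cyanophenyl does not move the reading beyond the scatter, with compound 3 still giving a low 10% at the single concentration tested. Nothing available offers a measured explanation for this result, so the step can only be reported as a reading.

With cyano as the only replacement for hydrogen shown at this position, it remains open whether a different group there, such as an amine, a carboxylic acid or a longer chain, would shift the inhibition beyond the scatter. From the compounds shown here alone, it also remains open whether cyano would read the same on another carbon of that ring, and a percentage at one concentration cannot show whether small differences in potency lie hidden beneath these low values.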